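The source may report more compounds than this note shows. Statements on the series, on what has been measured and on what is new or still open speak of the compounds shown alone.

The compounds share one core and differ only in the aromatic group attached to an aromatic nitrogen of a five-membered aromatic ring with 3 nitrogen. In an ADME assay on HEK293 cells (Homo sapiens) for inhibition, read by MTT assay, with a stated time of 48 h, tested at 25 uM (on this read-out lower numbers stand for less inhibition and higher numbers for more inhibition at the one concentration tested (going by the name of the read-out)), compound 1 `COc1ccccc1-n1cc(COc2ccc3c(c2)CCC3)nn1` gives 19.8%. Compound 2 `Cc1cccc(-n2cc(COc3ccc4c(c3)CCC4)nn2)c1` gives 23.4% in this assay. Within the data shown here, the one measured step, a number 3.6 percentage points higher from compound 1 to compound 2 (within the scatter), lies within the scatter, so exchanging one substituted phenyl for another did not move the read-out in any reliable way here.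

Compound 3 `Clc1ccc(-n2cc(COc3ccc4c(c3)CCC4)nn2)cc1` has no single number in this assay; for compound 3 the result is reported as "not determined" (no result reported), so it stands nowhere on the measured scale. Compound 4 `Brc1ccccc1-n1cc(COc2ccc3c(c2)CCC3)nn1` differs from compound 3 by 2-bromophenyl in place of 4-chlorophenyl on an aromatic nitrogen. Among the measured compounds shown here, no measured step shares this change, and compound 3 itself offers no starting value, so nothing can be said about the size or direction of the step from compound 3 to compound 4 beyond what the two measured compounds suggest. Both of those carry a substituted phenyl at the same nitrogen and sit close together at low inhibition, and their step is within the scatter. Compound 4 is therefore expected to give a similar low read-out in this assay, estimated at 22%, with a likely range from 8% to 38%.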

Compound 4, a percentage reported as inhibition, at one concentration (the size of the read-out at that concentration, not a potency): 16.5%
Estimate against measurement, compound 4: 5.5 percentage points above, and the stated range covers the measured number.
By their numbers in this assay, from the lowest: compounds 4, 1 and 2 (each within the scatter of the next).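

The cleanest new comparison is a number 3.3 percentage points lower from compound 1 to compound 4 (within the scatter), where bromo takes the place of methoxy on an aromatic carbon of the phenyl ring, and this exchange leaves the read-out unchanged within the usual scatter. The second comparison, a number 6.9 percentage points lower from compound 2 to compound 4 (within the scatter), points the same way, so in this assay the 2-methoxyphenyl, 3-methylphenyl and 2-bromophenyl groups on the aromatic nitrogen cannot be told apart, and none of the three compounds with a number goes against this. Nothing available here explains why these exchanges make so little difference to the read-out.

The compounds shown all carry a substituted phenyl at this nitrogen, so it remains open whether a different kind of group there, such as an aminophenyl, a carboxylic acid on the phenyl ring or a longer alkyl chain in place of the ring, would move the read-out beyond the scatter. On these data alone, the rest of the shared core stays the same throughout, so what a change there, such as adding an amine, would do to the read-out also remains open.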